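Hydroxy in Place of Methylsulfanyl on a Shared Core

This account rests on a few compounds, and the source may have more. Where it says the series, first, only, none or still open, it means among the compounds named here.

Compound 1: `COc1ccccc1N1CCN(CCC(O)c2ccc(Cl)c(Cl)c2)CC1`, 101%
Compound 2: `CSc1ccccc1N1CCN(CCC(O)c2ccc(Cl)c(Cl)c2)CC1`, 101%

Both measured compounds were tested in an assay on CHO cells for displacement of a labelled ligand from 5-hydroxytryptamine receptor 7 (Homo sapiens), read by scintillation counting, with a stated time of 60 min, tested at 10 uM; a lower number here means less inhibition, a higher number more inhibition at the concentration tested (going by the name of the read-out). In this assay compound 1 gives 101% and compound 2 gives 101%. Among the compounds with values here, the one step known, no change at the digits printed from compound 1 to compound 2 (within the scatter), shows that trading methoxy for methylsulfanyl on an aromatic carbon left the read-out unchanged. Compound 2 therefore stands level with compound 1 in this assay.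

Compound 3, `Oc1ccccc1N1CCN(CCC(O)c2ccc(Cl)c(Cl)c2)CC1`, has not yet been measured. It differs from compound 2 as follows: hydroxy in place of methylsulfanyl on an aromatic carbon. Within the data shown here, no measured step bears directly on a hydroxy group here; the only step available, from compound 1 to compound 2, concerns a different exchange and was flat. The expectation for compound 3 is therefore a step of a number 6 percentage points lower from compound 2 to compound 3 (within the scatter) in this assay, at most a small drop, and the estimated value for compound 3 is 95% with a range from 80% to 102%.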

Compound 3, a percentage reported as inhibition, at one concentration (the size of the read-out at that concentration, not a potency): 102%
The estimate for compound 3 lay 7 percentage points below the measured number; measured number inside the range.
By their numbers in this assay, from the lowest: compounds 1, 2 and 3 (each within the scatter of the next).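

In this assay, hydroxy in place of methylsulfanyl gave a number 1 percentage points higher from compound 2 to compound 3 (within the scatter), and hydrogen in place of methyl on the oxygen gave a number 1 percentage points higher from compound 1 to compound 3 (within the scatter). Within the data shown here, the earlier compounds showed only that one group without a hydrogen-bond donor could stand in for another at this place, ortho to a large group, whereas hydroxy brings such a donor and the read-out still stays within the scatter of the other two. Nothing available explains why this exchange makes no visible difference.

On these data alone, each number is the size of the read-out at one concentration rather than a potency, so any differences in potency among the three compounds remain open. The compounds shown also leave open how an amine or a carboxylic acid at this place would behave.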